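Phenyl-to-cyclohexyl swap on a thiourea: a second look

This account rests on a few compounds, and the source may have more. Where it says the series, first, only, none or still open, it means among the compounds named here.

Three thioureas sharing a pyridazinone-bearing core were measured in a functional assay on the whole organism with Rattus norvegicus as the target, at a dose of 100 mg/kg; a higher number here means more inhibition at the dose given (going by the name of the read-out), a lower number less inhibition. Compound 1 `O=c1ccc(-c2ccccc2)nn1CCCNC(=S)Nc1ccccc1` gives 12.1% and sits lowest of the three numbers, though its gap to compound 2 is within the scatter. Compound 3 `O=c1ccc(-c2ccccc2)nn1CCCCNC(=S)Nc1ccccc1` gives 38.4%, and compound 2 `O=c1ccc(-c2ccccc2)nn1CCCCNC(=S)NC1CCCCC1` gives 18.1%. Among the measured compounds shown here, the step of a number 20.3 percentage points lower from compound 3 to compound 2 (beyond the scatter) is the only single-site change among the measured compounds, and it is cyclohexyl in place of phenyl on an amide-type nitrogen. The difference between the core of compound 1 and the core of compound 3 is not broken down here.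

Compound 4 `O=c1ccc(-c2ccccc2)nn1CCCNC(=S)NC1CCCCC1` has not yet been measured. It differs from compound 1 by cyclohexyl in place of phenyl on an amide-type nitrogen, the same change as that from compound 3 to compound 2, at the same place. Resting on the step from compound 3 to compound 2, a downward step a number 6.1 percentage points lower from compound 1 to compound 4 (within the scatter) is expected from compound 1 to compound 4, though compound 1 starts low and the read-out cannot fall far. Compound 4 is therefore estimated at 6%, with a likely range of -5% to 18%.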

Compound 4, a percentage reported as inhibition, in the whole organism at one dose (the size of the read-out at that dose, not a potency): 23.6%
Beside the measured number, compound 4's estimate is 17.6 percentage points below it; the whole stated range lies below it.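

On the core of compound 1, cyclohexyl in place of phenyl on an amide-type nitrogen gives, in this assay, a number 11.5 percentage points higher from compound 1 to compound 4 (beyond the scatter). Set beside the earlier step on the other core, the same change does not carry over, not even in its direction: the same change on two cores in this assay, a number 20.3 percentage points lower (beyond the scatter) from compound 3 to compound 2 and a number 11.5 percentage points higher (beyond the scatter) from compound 1 to compound 4, 31.8 percentage points apart, beyond the scatter of two such steps. In this series, then, the result of this swap on one core cannot be taken as a guide to its result on the other, though the two pairs do not show what in the cores separates them, and they set no rule for any further core.

As far as these compounds go, whether benzyl or an open-chain hexyl group on that same nitrogen would also part the two cores in this way remains open. So does the question of how the swap from phenyl to cyclohexyl would behave on a core with a longer chain, which would show whether the opposite steps seen here extend beyond these four compounds.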